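Chain extension at the alkyne in a nucleoside series

The source may hold more compounds than are shown below. What is called first, only, known or untested is meant among the compounds shown, and "the series" means these compounds.

Measured so far in a functional assay on HEL cells (Homo sapiens) for cytotoxicity; on this read-out higher numbers stand for lower toxicity in this test and lower numbers for higher toxicity in this test:
compound 1 `CCCCCCC#Cc1cc2cn([C@@H]3O[C@H](CO)[C@@H](O)[C@H]3O)c(=O)nc2o1` gives >= 133000 nM.
compound 2 `CCCCCCC#Cc1cc2cn([C@@H]3O[C@H](CO)[C@@H](O)[C@@H]3O)c(=O)nc2o1` gives 133000 nM.

For compound 1 the value in this assay is a limit of the measurement, not a number. The step of a number no higher from compound 1 to compound 2 (the limit leaves the size open) rests only on configuration the fact that compounds 1 and 2 differ only in the configuration as drawn and is cut off by the limit (the limit of >= 133000 nM in this assay, at which 1 of the 2 values shown sits), so it carries nothing about a change on the chain. Compound 3 `CCCCCCCCC#Cc1cc2cn([C@@H]3O[C@H](CO)[C@@H](O)[C@H]3O)c(=O)nc2o1` differs from compound 1 by ethyl in place of hydrogen on a saturated chain carbon, six bonds along the chain from a triple-bonded carbon. Going by the values given here, no measured step covers such a change, so no movement beyond the scatter is expected. Compound 3 is therefore estimated at 133000 nM, range 60000 nM to 300000 nM, a step of a number no higher from compound 1 to compound 3 (the limit leaves the size open) of about nothing, most likely reported again as a limit.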

Compound 3, minimum cytotoxic concentration: 49000 nM
Estimate against measurement, compound 3: 2.7-fold (0.43 log units) above, and the stated range ends above it.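

Ethyl in place of hydrogen on a saturated chain carbon gives an at least 2.7-fold lower number from compound 1 to compound 3 (0.43 log units; beyond the scatter) in this assay. Going by these compounds alone, this is the first change on the chain to move the read-out beyond the scatter, so this place is not silent in this test. Compound 1 gives >= 133000 nM, which is a limit, so the size of the step stays open: the limit of >= 133000 nM in this assay, at which 1 of the 3 values shown sits.

As far as these compounds go, whether a longer chain would lower the number further, or an amine at the chain end would reverse the step, stays open. So does whether the same change on compound 2 gives a similar step.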